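Dropping the chloro on the amide-side aryl ring

The compounds below may be only part of what the source reports. "The series", "measured", "known", "first", "only" and "open" are said of these compounds alone.

Compound 1 `CC(C)(C)c1ccc(CN2CCN(C(=O)CCc3cc(-c4ccc(F)cc4)n(-c4ccc(Cl)cc4)n3)CC2)cc1`: 2600 nM
Compound 2 `CC(C)(C)c1ccc(CN2CCN(C(=O)CCc3cc(-c4ccc(C(F)(F)F)cc4)n(-c4ccc(Cl)cc4)n3)CC2)cc1`: 8000 nM

In an assay on isolated protein for inhibition of Polyunsaturated fatty acid 5-lipoxygenase (Homo sapiens), read by HPLC, with a stated time of 15 min, in the presence of a further agent that is not named here (on this read-out lower numbers stand for stronger inhibition and higher numbers for weaker inhibition), compound 1 gives the lower of the two numbers; compound 2 sits a 3.1-fold higher number from compound 1 to compound 2 (0.49 log units; beyond the scatter) away. Compound 3 `CC(C)(C)c1ccc(CN2CCN(C(=O)CCc3cc(-c4ccc(F)cc4)n(-c4ccccc4)n3)CC2)cc1` is not yet measured. It differs from compound 1 by hydrogen in place of chloro on an aromatic carbon, on an aromatic carbon of a six-membered aromatic ring of carbon only. Within the data shown here, no measured step touches this ring; the one known step concerns the other aryl ring, so it does not bear on this change. Compound 3 is therefore expected to stay near compound 1, with a small step of a 1.3-fold higher number from compound 1 to compound 3 (0.13 log units; within the scatter) estimated, likely within the scatter. The estimate for compound 3 is 3500 nM, ranging from 1500 nM to 8000 nM.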

Compound 3, half-maximal inhibitory concentration: 2500 nM
For compound 3 the middle estimate is 1.4-fold (0.15 log units) above the measured one, within the range that was stated.
By their numbers in this assay, from the lowest: compounds 3 and 1 (each within the scatter of the next); then compound 2.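

In this assay, hydrogen in place of chloro on this ring gives a 1.0-fold lower number from compound 1 to compound 3 (0.02 log units; within the scatter) and so the chloro on the 4-chlorophenyl ring can go without a step beyond the scatter. The one earlier step, on the other aryl ring, was a 3.1-fold higher number from compound 1 to compound 2 (0.49 log units; beyond the scatter) and thus did lie beyond the scatter, so the two aryl rings have so far responded differently to the single changes shown. Nothing available explains this result.

As far as these compounds go, what remains open is how this position responds to groups other than chloro and hydrogen. A methoxy, an amine or a carboxylic acid in that place could still separate from compound 3.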